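A few compounds are considered here, and "the series" means these few. Any claim that something is new, unique, unknown or untested is made for them only; others in the source may bear on it.

Compound 1 `CCC[C@]1(C(=O)N2CC[C@](c3ccc(C(F)(C(F)(F)F)C(F)(F)F)cc3)(S(=O)(=O)c3ccc(F)cc3)C2)CC[C@H](C(=O)O)CC1` gives "not determined" (no result reported)
Compound 2 `O=C([C@H]1CC[C@H](CO)CC1)N1CC[C@](c2ccc(C(F)(C(F)(F)F)C(F)(F)F)cc2)(S(=O)(=O)c2ccc(F)cc2)C1` gives 75%

Within the data shown here, in an ADME assay on microsomes from liver (Homo sapiens) for metabolic stability, with a stated time of 10 min (on this read-out lower numbers stand for a less stable compound and higher numbers for a more stable compound), compound 2 gives 75% as the only number so far. Compound 1 has no reported result, so compound 2 cannot yet be ranked against any other compound. Compound 3 `O=C(C1CCS(=O)(=O)CC1)N1CC[C@](c2ccc(C(F)(C(F)(F)F)C(F)(F)F)cc2)(S(=O)(=O)c2ccc(F)cc2)C1` has not been measured. It keeps the rest of compound 2 but carries 1,1-dioxothian-4-yl in place of 4-(hydroxymethyl)cyclohexyl on a carbonyl carbon. Among the measured compounds shown here, no measured pair of compounds shows what a swap of this kind does in this assay here, so any forecast is loose. The expected step of a number 5 percentage points higher from compound 2 to compound 3 (within the scatter) is small and slightly upward, and it is not expected to go beyond the usual scatter of repeated measurements. For compound 3 the estimated value is 80% (expected range 60% to 95%).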

Compound 3, percent of the compound remaining: 93%
The estimate for compound 3 lay 13 percentage points below the measured number, and the stated range covers the measured number.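

Among these compounds, on the carbonyl carbon whose other neighbour is the amide-type nitrogen in a ring, putting 1,1-dioxothian-4-yl in place of 4-(hydroxymethyl)cyclohexyl gives, in this assay, a number 18 percentage points higher from compound 2 to compound 3 (beyond the scatter) as the first readable step at this position. The step shows that this exchange alone, with the rest of the molecule unchanged, can shift the read-out by more than the usual scatter, towards a more stable compound. No measurement shown here accounts for the rise.

The change removes the hydroxymethyl group and alters the ring in one move, leaving open which of the two matters. Also open, as far as these compounds go, is how a plain cyclohexyl, a tetrahydropyran-4-yl ring or a cyclohexyl ring carrying an amine would behave at this position.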